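Swapping a ring methyl for hydrogen in compound 2

A few compounds are considered here, and "the series" means these few. Any claim that something is new, unique, unknown or untested is made for them only; others in the source may bear on it.

Three related compounds have been measured so far in an ADME assay on microsomes from liver (Rattus norvegicus) for metabolic stability (on this read-out lower numbers stand for slow clearance and higher numbers for fast clearance), so far. Here compound 1 `CNc1nc(NC(C#N)(C2CC2)C2CC2)nc(-n2cncn2)n1` gives 3.7 mL/min/kg as the lowest number. Compound 2 `CNc1nc(NC2(C#N)CCCC(C)C2)nc(-n2cncn2)n1` reads 96 mL/min/kg and is the second highest of the three, clearly apart from both others. Compound 3 `CNc1nc(NC2(C#N)CCCCCC2)nc(-n2cncn2)n1` gives 276 mL/min/kg at the top. Compound 4 `CNc1nc(NC2(C#N)CCCCC2)nc(-n2cncn2)n1` differs from compound 2 in one place (hydrogen in place of methyl on a saturated ring carbon) with hydrogen in place of methyl on a saturated ring carbon. Among the compounds with values here, no measured pair shows this change alone, so any forecast is loose. The expected change is a modest fall in clearance, with a 1.9-fold lower number from compound 2 to compound 4 (0.28 log units; within the scatter) as the estimate and the usual scatter close by. Compound 4 is expected at 50 mL/min/kg with a likely range from 20 mL/min/kg to 120 mL/min/kg on this read-out.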

Compound 4, clearance: 52 mL/min/kg
The estimate for compound 4 lay 1.0-fold (0.02 log units) below the measured number, within the range that was stated.
By their numbers in this assay, from the lowest: compound 1; then compounds 4 and 2 (each within the scatter of the next); then compound 3.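

In this assay, within the data shown here, hydrogen in place of methyl on a saturated ring carbon gives a 1.8-fold lower number from compound 2 to compound 4 (0.27 log units; within the scatter) and this pair is the first to show that change alone. At this ring carbon, two ring bonds from the ring atom that bears a cyano group, the methyl therefore makes no difference that can be told from the scatter. Nothing measured here explains why the two compounds read alike.

From the compounds shown here alone, whether an ethyl group, a hydroxyl or an amine at this ring carbon would move the number remains open. So does whether a methyl on another ring carbon would behave the same way.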